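Styryl replacement for the alkyne on the core of compound 1

A few compounds are considered here, and "the series" means these few. Any claim that something is new, unique, unknown or untested is made for them only; others in the source may bear on it.

Compound 1 `CCCC#Cc1cc([C@@H]2O[C@H](CO)[C@@H](O)[C@H]2O)n2ncnc(N)c12` gives 400 nM in a functional assay on NCI-H460 cells (Homo sapiens) for antiproliferative activity, with a stated time of 72 h (on this read-out lower numbers stand for stronger inhibition and higher numbers for weaker inhibition), the higher of the two numbers available, with compound 2 `Nc1ncnn2c([C@@H]3O[C@H](CO)[C@@H](O)[C@H]3O)cc(C#CC3CC3)c12` at 80 nM. Compound 3 `Nc1ncnn2c([C@@H]3O[C@H](CO)[C@@H](O)[C@H]3O)cc(-c3ccccc3F)c12` reaches only the limit > 100000 nM in this assay. The change to compound 4 `Nc1ncnn2c([C@@H]3O[C@H](CO)[C@@H](O)[C@H]3O)cc(/C=C/c3ccccc3)c12` is 2-phenylethenyl in place of pent-1-yn-1-yl on an aromatic carbon. Going by the values given here, two measured steps bear on it: a 5.0-fold lower number from compound 1 to compound 2 (0.70 log units; beyond the scatter), a modest shift within the alkyne pair, and an at least 250-fold higher number from compound 1 to compound 3 (2.39 log units; beyond the scatter), where an aromatic ring placed directly on the core pushes the value beyond (the limit of > 100000 nM in this assay, at which 1 of the 3 values shown sits). Compound 4 keeps a two-carbon linker yet carries a phenyl, so a large rise in this assay is expected, though not necessarily to the limit. The estimate for compound 4 is 10000 nM, range 1500 nM to 100000 nM, an expected 25-fold higher number from compound 1 to compound 4 (1.40 log units; beyond the scatter).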

Compound 4, half-maximal inhibitory concentration: 3700 nM
For compound 4 the middle estimate is 2.7-fold (0.43 log units) above the measured one; measured number inside the range.
By their numbers in this assay, from the lowest: compound 2; then compound 1; then compound 4. At a limit, above all of these: compound 3.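

A phenyl ring held on the 2-phenylethenyl linker is far better accepted at this position than the 2-fluorophenyl ring placed directly on the core, with an at least 27-fold lower number from compound 3 to compound 4 (1.43 log units; beyond the scatter). It still does not reach the alkynes in this assay, with a 9.3-fold higher number from compound 1 to compound 4 (0.97 log units; beyond the scatter) and a 46-fold higher number from compound 2 to compound 4 (1.67 log units; beyond the scatter). Compound 3 remains a limit and not a number: the limit of > 100000 nM in this assay, at which 1 of the 4 values shown sits.

The share of the double bond and the share of the phenyl ring in this loss stay unseparated. A 2-phenylethynyl group or a pent-1-en-1-yl chain on the same carbon would divide the two.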